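The source may hold more compounds than are shown below. What is called first, only, known or untested is meant among the compounds shown, and "the series" means these compounds.

Series record in an ADME assay on THP-1 cells (Homo sapiens) for cytotoxicity, read by resazurin assay, with a stated time of 72 h; on this read-out lower numbers stand for higher toxicity in this test and higher numbers for lower toxicity in this test:
compound 1 `Cc1cccc(C(=O)/C=C/c2ccc([N+](=O)[O-])o2)c1`: 42100 nM
compound 2 `CCCCc1ccc(C(=O)/C=C/c2ccc([N+](=O)[O-])s2)cc1`: 17100 nM
compound 3 `O=C(/C=C/c1ccc([N+](=O)[O-])o1)c1ccc(-c2ccccc2)cc1`: 50400 nM

Compound 2 gives the lowest of the three numbers in this assay; compound 1 and compound 3 both sit higher, each beyond the scatter from compound 2. Compound 4 `CSc1ccc(C(=O)/C=C/c2ccc([N+](=O)[O-])s2)cc1` is not yet measured. It differs from compound 2 in one place: methylsulfanyl in place of butyl on an aromatic carbon. Among the measured compounds shown here, no pair of measured compounds differs in exactly one place, so no measured step in this assay serves as a guide for this change. A step from compound 2 to compound 4 of modest size is expected, leaning toward a higher number but with direction uncertain, and the number for compound 4 is expected to stay nearer compound 2 than compound 1 or compound 3. Estimate for compound 4: 24000 nM (range 10000 nM to 60000 nM), which would mean an expected step of a 1.4-fold higher number from compound 2 to compound 4 (0.15 log units; within the scatter).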

Compound 4, half-maximal cytotoxic concentration: 8560 nM
For compound 4 the middle estimate is 2.8-fold (0.45 log units) above the measured one; the measured number lies below the stated range.
By their numbers in this assay, from the lowest: compounds 4 and 2 (each within the scatter of the next); then compounds 1 and 3 (each within the scatter of the next).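

Among the compounds shown here, at the aromatic carbon para to a large group, methylsulfanyl in place of butyl provides the first single-place comparison in this assay (a 2.0-fold lower number from compound 2 to compound 4 (0.30 log units; within the scatter)). This position therefore accepts the exchange without a change beyond the scatter, and compound 2 and compound 4 cannot be told apart here. No supporting measurement bears on this result.

As far as these compounds go, whether an amine, a carboxylic acid or a longer chain such as octyl at this position would move the number beyond the scatter remains open. Also open, from the compounds shown here alone, is whether the same exchange would behave alike on the core of compound 1.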